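The source may report more compounds than this note shows. Statements on the series, on what has been measured and on what is new or still open speak of the compounds shown alone.

Working notes on the series, cytotoxicity arm.

Compound 3 `Cc1ccccc1-c1nn(-c2ccc(F)cc2F)cc1CNC1CCN(S(C)(=O)=O)CC1` is known in an ADME assay on Huh-7 cells (Homo sapiens) for cytotoxicity (a higher number here means that more compound is tolerated, a lower number that less compound is tolerated), only as a limit: compound 3 gives > 20000 nM, so its value is not a number. Compound 1 `Cc1ccccc1CNc1nn(-c2ccc(F)cc2F)cc1CNCCN1CCN(C)CC1` likewise sits at a limit in this assay, compound 1 giving > 20000 nM. Compound 2 `CN1CCN(CCNCc2cn(-c3ccc(F)cc3F)nc2-c2ccc(Cl)cc2)CC1` gives 19000 nM in this assay. For the measured compounds named here, the one measured step, an at least 1.0-fold lower number from compound 1 to compound 2 (0.02 log units; that floor lies within the scatter), exchanges 4-chlorophenyl for (2-methylbenzyl)amino on an aromatic carbon and stays within the scatter, so it shows nothing beyond this assay's ceiling (the limit of > 20000 nM in this assay, at which 2 of the 3 values shown sit).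

Compound 4 `Cc1ccccc1-c1nn(-c2ccc(F)cc2F)cc1CNCCN1CCCCC1` is the next compound. It differs from compound 3 as follows: 2-(piperidin-1-yl)ethyl in place of 1-(methylsulfonyl)piperidin-4-yl on an amine nitrogen. Going by the values given here, none of the measured steps exchanges a 1-(methylsulfonyl)piperidin-4-yl for a 2-(piperidin-1-yl)ethyl on an amine nitrogen, so no step bears directly on this change. Among the compounds with values here, the only guidance is that all three measured compounds sit at or close to the limit, with compound 2 the one compound that returned a number. The step of a number no higher from compound 3 to compound 4 (the limit leaves the size open) is therefore expected to stay within the scatter. Compound 4 is estimated at 20000 nM, with a range from 8000 nM to 40000 nM, and a limit rather than a number is about as likely as not.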

Compound 4, half-maximal cytotoxic concentration: > 20000 nM
Compound 4: no number, only a limit; the forecaster's own chance of this, stated with the estimate: 50%; the middle value sits exactly at the limit.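

In this assay compound 4 gives > 20000 nM as a limit and not a number. Compound 3 is likewise known only as a limit, so no step can be read between compound 3 and compound 4. Still open is how far compound 1, compound 3 and compound 4 lie beyond the ceiling: the limit of > 20000 nM in this assay, at which 3 of the 4 values shown sit.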